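The source may report more compounds than this note shows. Statements on the series, on what has been measured and on what is new or still open speak of the compounds shown alone.

Compound 1, `COc1ccc(/C=C/C(=O)c2ccc(OC)c3c2OC(C)(C)C=C3)c(F)c1`, was tested in a functional assay on SK-OV-3 cells (Homo sapiens) for antiproliferative activity, read by MTT assay, with a stated time of 24 h (a higher number here means a weaker inhibitor, a lower number a stronger inhibitor), where compound 1 gives 4880 nM. Among the compounds that return a number in this assay, compound 1 has the lowest one. Compound 2, `COc1ccc(C(=O)/C=C/c2ccc3ccccc3c2)c2c1C=CC(C)(C)O2`, gives 7650 nM in this assay, and the gap between compound 1 and compound 2 lies within the usual scatter of repeated measurements, so no order can be drawn between them. Compound 3, `COc1ccc(C(=O)/C=C/c2ccc(N(c3ccccc3)c3ccccc3)cc2)c2c1C=CC(C)(C)O2`, sits at the limit of > 10000 nM in this assay, at which 1 of the 3 values shown sits. For compound 3 the value > 10000 nM is a limit of the assay and not a number.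

Compound 4, `COc1ccc(C(=O)/C=C/c2ccco2)c2c1C=CC(C)(C)O2`, has not yet been measured in this assay. It differs from compound 1 in one place: furan-2-yl in place of 2-fluoro-4-methoxyphenyl on a double-bonded chain carbon bound to a double-bonded chain carbon. Within the data shown here, no pair of measured compounds differing in one place is available, so the expectation for compound 4 rests on the structural change alone. Among the measured compounds shown here, the two numbers and the one limit all sit at the weak end of the assay, and none of the measured compounds carries a furan-2-yl, so the change gives no firm direction. The step of a 1.3-fold higher number from compound 1 to compound 4 (0.12 log units; within the scatter) is expected to stay within or only just beyond the scatter, with a weaker inhibitor somewhat more likely than a stronger one. Compound 4 is therefore estimated at 6500 nM in this assay, with a range from 2500 nM to 16000 nM.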

Compound 4, half-maximal inhibitory concentration: > 10000 nM
Compound 4 gave a limit, no number; the forecaster's own chance of this, stated with the estimate: 30%; at least 1.5-fold (0.18 log units) between middle value and limit.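

Among these compounds, compound 4 gives the first readable step at this position, with furan-2-yl in place of 2-fluoro-4-methoxyphenyl on a double-bonded chain carbon bound to a double-bonded chain carbon: in this assay, the change gives an at least 2.0-fold higher number from compound 1 to compound 4 (0.31 log units; beyond the scatter), so the result here does depend on which ring sits at this place. The value for compound 4, > 10000 nM, is a limit of the assay and not a number, so the step shows a minimum size and the true gap could be larger. Compound 4 now stands with compound 3 at the same limit, and neither can be placed in order against the other: the limit of > 10000 nM in this assay, at which 2 of the 4 values shown sit.

The step swaps the whole ring at once, so these compounds cannot separate the effect of the five-membered furan ring from the loss of the fluorine or of the methoxy group. A plain phenyl, a phenyl carrying only a fluorine, a phenyl carrying only a methoxy group, or a thiophene ring at the same place would be needed to pull these parts apart.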